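A few compounds are considered here, and "the series" means these few. Any claim that something is new, unique, unknown or untested is made for them only; others in the source may bear on it.

Measured so far:
compound 1 `COc1ccc(-c2cc(C(C)=O)c3[nH]c(-c4ccccc4)cc3c2)cc1` – 33.9%
compound 2 `CC(=O)c1cc(-c2ccccc2)cc2cc(-c3ccc(F)cc3)[nH]c12` – 76.9%
compound 3 `CC(=O)c1cc(-c2ccc(F)cc2)cc2cc(-c3ccc(F)cc3)[nH]c12` – 47.4%

In a functional assay on HeLa cells (Homo sapiens) for cytotoxicity, read by MTT assay, with a stated time of 2 days, tested at 10 uM (a lower number here means a stronger effect, a higher number a weaker effect of the compound at the concentration tested), compound 3 stands second highest of the three numbers. Its nearest neighbour is compound 1, whose number is lower, beyond the scatter; its furthest is compound 2, whose number is higher, again beyond the scatter. For the measured compounds named here, the only single-place step among the measured compounds is a number 29.5 percentage points lower from compound 2 to compound 3 (beyond the scatter), a modest lowering. Compound 4 `COc1ccc(-c2cc(C(C)=O)c3[nH]c(-c4ccc(F)cc4)cc3c2)cc1` is not yet measured. Its change from compound 3: methoxy in place of fluoro on an aromatic carbon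

Going by the values given here, no measured step follows this same change, so it is judged only from what the values show. Compound 1, which carries the methoxyphenyl together with an unsubstituted phenyl, gives 33.9%, a lower number than compound 3. Compound 4 keeps the fluorophenyl of compound 3 and takes up the methoxyphenyl of compound 1, and a number near compound 1 or modestly below compound 3 is expected. Compound 4 is therefore estimated at 36%, between 20% and 55%, which is an expected step of a number 11.4 percentage points lower from compound 3 to compound 4 (beyond the scatter).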

Compound 4, a percentage reported as activity, at one concentration (the size of the read-out at that concentration, not a potency): 46.5%
Compound 4: the middle estimate sits 10.5 percentage points below what was measured; low and high end bracket the measured number.
By their numbers in this assay, from the lowest: compound 1; then compounds 4 and 3 (each within the scatter of the next); then compound 2.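

In this assay, with the 4-fluorophenyl held in place on the other side of the shared core, going from 4-fluorophenyl to 4-methoxyphenyl at this position gives a number 0.9 percentage points lower from compound 3 to compound 4 (within the scatter) and leaves compounds 3 and 4 level. Against the unsubstituted phenyl, methoxy in place of hydrogen gives a number 30.4 percentage points lower from compound 2 to compound 4 (beyond the scatter) so on this core either group, fluoro or methoxy, goes with a lower number than hydrogen. Fluoro in place of hydrogen gives a number 12.6 percentage points higher from compound 1 to compound 4 (beyond the scatter). This change does not behave alike across the series: the same change on two cores in this assay, a number 29.5 percentage points lower (beyond the scatter) from compound 2 to compound 3 and a number 12.6 percentage points higher (beyond the scatter) from compound 1 to compound 4, 42.1 percentage points apart, beyond the scatter of two such steps.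

On these data alone, whether this position tolerates groups beyond fluoro and methoxy, such as an amine or a carboxylic acid, stays open. Also open, as far as these compounds go, is what a longer chain in place of the acetyl group would do.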